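Changing the aryl group on the sulfonyl sulfur again

The source may report more compounds than this note shows. Statements on the series, on what has been measured and on what is new or still open speak of the compounds shown alone.

Three compounds share one core and differ only in the aryl group on a sulfonyl sulfur. In an assay on isolated protein for displacement of a labelled ligand from metabotropic glutamate receptor 5 (Homo sapiens), with a stated time of 60 min, tested at 1 uM (on this read-out lower numbers stand for less inhibition and higher numbers for more inhibition at the one concentration tested (going by the name of the read-out)), compound 1 `CC1CCN(c2c(S(=O)(=O)c3cc(Cl)cc(Cl)c3)cnc3cc(Cl)ccc23)CC1` gives 93%, compound 2 `Cc1ccc(S(=O)(=O)c2cnc3cc(Cl)ccc3c2N2CCC(C)CC2)cc1` gives 94% and compound 3 `CC1CCN(c2c(S(=O)(=O)c3ccc(F)c(F)c3)cnc3cc(Cl)ccc23)CC1` gives 90%. Compound 3 sits close to both, differing by a number 3 percentage points lower from compound 1 to compound 3 (within the scatter) and by a number 4 percentage points lower from compound 2 to compound 3 (within the scatter), and the remaining pair differs by a number 1 percentage points higher from compound 1 to compound 2 (within the scatter). Compound 4 `COc1ccc(S(=O)(=O)c2cnc3cc(Cl)ccc3c2N2CCC(C)CC2)cc1Cl` changes the same position: 3-chloro-4-methoxyphenyl in place of 3,4-difluorophenyl on a sulfonyl sulfur. Every step of this kind so far stayed within the scatter, so a step beyond it is not expected here either, giving an estimated a number 1 percentage points higher from compound 3 to compound 4 (within the scatter). Compound 4 is therefore expected to give about 91%, between 80% and 98%.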

Compound 4, a percentage reported as inhibition, at one concentration (the size of the read-out at that concentration, not a potency): 93%
Estimate against measurement, compound 4: 2 percentage points below; low and high end bracket the measured number.
By their numbers in this assay, from the lowest: compounds 3, 1, 4 and 2 (each within the scatter of the next).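

The 3-chloro-4-methoxyphenyl group is the only aryl group among these four with an oxygen and a hydrogen-bond acceptor, yet in this assay the step is small: a number 3 percentage points higher from compound 3 to compound 4 (within the scatter). The comparisons with the other two aryl groups read the same way, with a number 1 percentage points lower from compound 2 to compound 4 (within the scatter) and no change at the digits printed from compound 1 to compound 4 (within the scatter), so this position accepts the new group with no readable change at this one concentration. Nothing available explains this result.

As far as these compounds go, whether an aryl group carrying an amine or a carboxylic acid would behave the same remains open. So does whether these four compounds differ in potency, which a single concentration cannot show.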